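The source may hold more compounds than are shown below. What is called first, only, known or untested is meant among the compounds shown, and "the series" means these compounds.

Measured compounds:
compound 1 `COc1ccc(CNc2nc([SeH])nc3ccccc23)cc1` gives > 100000 nM
compound 2 `CSc1ccc(CNc2nc([SeH])nc3ccccc23)cc1` gives 58200 nM
compound 3 `[SeH]c1nc(NCc2ccccc2)c2ccccc2n1` gives > 100000 nM

Going by the values given here, in an ADME assay on BEAS-2B cells (Homo sapiens) for cytotoxicity, read by MTT assay, with a stated time of 72 h (a higher number here means a weaker inhibitor of growth, a lower number a stronger inhibitor of growth), compound 2 stands as the only compound of the three with a number; the other two values are limits of the assay, namely (the limit of > 100000 nM in this assay, at which 2 of the 3 values shown sit). Compound 1 sits at that limit. Compound 3 sits at that limit as well. Compound 4 `CSc1ccc(CNc2nc(SC)nc3ccccc23)cc1` differs from compound 2 in one place: a group of 2 heavy atoms (1 carbon, 1 sulfur; no ring) in place of one selenium atom, on an aromatic carbon. Among the compounds with values here, none of the measured steps touches that place. The step from compound 1 to compound 2 (an at least 1.7-fold lower number from compound 1 to compound 2 (0.23 log units; that floor lies within the scatter)) and the step from compound 2 to compound 3 (an at least 1.7-fold higher number from compound 2 to compound 3 (0.23 log units; that floor lies within the scatter)) concern the methylsulfanyl and methoxy groups on the other ring, and the step from compound 1 to compound 3 (a step that the two limits leave unreadable from compound 1 to compound 3) cannot be read. Within the data shown here, no measured step therefore gives guidance on replacing selenium by methylsulfanyl, and no step beyond the scatter is expected in this assay. Compound 4 is estimated at 60000 nM, between 25000 nM and 140000 nM, which would mean an expected step of a 1.0-fold higher number from compound 2 to compound 4 (0.01 log units; within the scatter).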

Compound 4, concentration for total growth inhibition: 59100 nM
The estimate for compound 4 lay 1.0-fold (0.01 log units) above the measured number; the range from low to high includes it.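

In this assay, the change at this position, on an aromatic carbon between two ring nitrogen atoms, gives a 1.0-fold higher number from compound 2 to compound 4 (0.01 log units; within the scatter). Going by these compounds alone, the earlier steps concerned only the other ring, so this is the first reading at this place: with methylsulfanyl on that other ring, methylsulfanyl can stand in place of the selenium atom without a step beyond the scatter, and selenium is not needed for the number seen for compound 2. The data shown give no cause for this result.

From the compounds shown here alone, whether the same exchange holds with methoxy or with hydrogen on the other ring stays open, and the steps that rest on two limits cannot be read. Also open, going by these compounds, is what an amine, a hydroxyl group or a longer chain such as ethylsulfanyl at this place would give in this assay.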